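The source may report more compounds than this note shows. Statements on the series, on what has been measured and on what is new or still open speak of the compounds shown alone.

Of the compounds shown here, three sharing one core have been measured in a functional assay on cells (Hepatocyte, Rattus norvegicus) for inhibition, read by scintillation counting, with a stated time of 4 h; a higher number here means a weaker inhibitor, a lower number a stronger inhibitor. Compound 1 `CC(C)c1c(C(=O)NCc2ccccc2)nc(-c2ccc(F)cc2)n1CC[C@@H](O)C[C@@H](O)CC(=O)O` gives 0.3 nM in this assay. Compound 2 `COc1cccc(CNC(=O)c2nc(-c3ccc(F)cc3)n(CC[C@@H](O)C[C@@H](O)CC(=O)O)c2C2CC2)c1` gives 0.2 nM, and compound 3 `CN(C)S(=O)(=O)c1ccc(CNC(=O)c2nc(-c3ccc(F)cc3)n(CC[C@@H](O)C[C@@H](O)CC(=O)O)c2C2CC2)cc1` gives 0.5 nM. Compound 3 thus carries the highest number of the three; its nearest neighbour is compound 1, whose value lies within the usual scatter of it, while compound 2 sits further away, with a gap beyond the scatter. Among the measured compounds shown here, the single measured step that alters the same place on the molecule is a 2.5-fold higher number from compound 2 to compound 3 (0.40 log units; beyond the scatter), a modest rise in the number.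

Compound 4 `COc1ccccc1CNC(=O)c1nc(-c2ccc(F)cc2)n(CC[C@@H](O)C[C@@H](O)CC(=O)O)c1C1CC1` has not yet been measured. It differs from compound 3 by 2-methoxyphenyl in place of 4-(dimethylsulfamoyl)phenyl on a saturated chain carbon bound to an amide-type nitrogen. This is nearly the reverse of the measured step, since a methoxyphenyl group again takes the place of 4-(dimethylsulfamoyl)phenyl, though the entering group is 2-methoxyphenyl rather than the 3-methoxyphenyl of compound 2. On that basis a lower number than compound 3 is expected, roughly undoing the rise seen in compound 3. A step of about a 2.0-fold lower number from compound 3 to compound 4 (0.30 log units; within the scatter) is therefore expected. The estimate for compound 4 in this assay is 0.25 nM, with a likely range between 0.1 nM and 0.6 nM.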

Compound 4, half-maximal inhibitory concentration: 0.1 nM
The estimate for compound 4 lay 2.5-fold (0.40 log units) above the measured number; the range from low to high includes it.
By their numbers in this assay, from the lowest: compounds 4, 2, 1 and 3 (each within the scatter of the next, the first and the last beyond it).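

In this assay, the change on a saturated chain carbon bound to an amide-type nitrogen from 4-(dimethylsulfamoyl)phenyl to 2-methoxyphenyl gives a 5.0-fold lower number from compound 3 to compound 4 (0.70 log units; beyond the scatter), so a second methoxyphenyl group now stands apart from the sulfamoyl-bearing ring, in the same direction as compound 2 did. The two methoxyphenyl groups, however, cannot be told apart at this place: the comparison gives a 2.0-fold lower number from compound 2 to compound 4 (0.30 log units; within the scatter), so shifting the methoxy group around the ring has no effect that this assay can resolve, and the difference from compound 3 holds for both. Nothing measured here offers a reason for the difference between these groups.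

The compounds shown leave open how a pyridine ring, or a phenyl ring carrying an amine or a carboxylic acid, would read at this place. Among the compounds shown here, they also leave open whether the same exchange would give a similar step if the substituent from compound 1 replaced the one that compounds 2, 3 and 4 carry on the shared core.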